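The compounds below may be only part of what the source reports. "The series", "measured", "known", "first", "only" and "open" are said of these compounds alone.

In a functional assay on LNCaP cells (Homo sapiens) for antiproliferative activity, read by propidium iodide staining, with a stated time of 96 h (a higher number here means a weaker inhibitor, a lower number a stronger inhibitor), compound 1, with the structure `CC(O)(CSc1cccc(C(F)(F)F)c1)C(=O)Nc1ccc(S(F)(F)(F)(F)F)cc1`, gives 18300 nM. Compound 2, with the structure `CC(O)(CSc1cc(C(F)(F)F)cc(C(F)(F)F)c1)C(=O)Nc1ccc(S(F)(F)(F)(F)F)cc1`, differs from it in one place: trifluoromethyl in place of hydrogen on an aromatic carbon. In this assay compound 2 gives 17600 nM. That change leaves the reading almost unmoved, as a 1.0-fold lower number from compound 1 to compound 2 (0.02 log units; within the scatter) shows.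

Compound 3, with the structure `CC(O)(CSc1cccc(C(F)(F)F)c1)C(=O)Nc1cccc(S(F)(F)(F)(F)F)c1`, shares its atoms with compound 1 but has them joined differently; the difference between the two cores is not broken down here. In this assay compound 3 gives 12700 nM, which sits within the usual scatter of the readings for compound 1 and compound 2, so no order among the three can be claimed.

Compound 4, with the structure `CC(O)(CSc1cc(C(F)(F)F)cc(C(F)(F)F)c1)C(=O)Nc1cccc(S(F)(F)(F)(F)F)c1`, has not yet been measured. It differs from compound 3 by the same change already seen between compound 1 and compound 2: trifluoromethyl in place of hydrogen on an aromatic carbon.

For compound 4 the expected step is a 1.0-fold lower number from compound 3 to compound 4 (0.01 log units; within the scatter), a guess that rests on the earlier step of the same change, because a 1.0-fold lower number from compound 1 to compound 2 (0.02 log units; within the scatter) stayed within the scatter. On that basis compound 4 is estimated to give 12500 nM in this assay, most likely between 6500 nM and 25000 nM.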

Compound 4, half-maximal inhibitory concentration: 4800 nM
Estimate against measurement, compound 4: 2.6-fold (0.42 log units) above; measured number below the stated range.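

In this assay, trifluoromethyl in place of hydrogen gives a 2.6-fold lower number from compound 3 to compound 4 (0.42 log units; beyond the scatter), a modest step but one larger than the usual scatter. The same change gave no step beyond the scatter on the core of compound 1, yet the gap between the two results is too small to count as a real difference between the cores: the same change on two cores in this assay, a 1.0-fold lower number (0.02 log units; within the scatter) from compound 1 to compound 2 and a 2.6-fold lower number (0.42 log units; beyond the scatter) from compound 3 to compound 4, 2.5-fold (0.41 log units) apart, within the scatter of two such steps. The two cores may therefore respond alike or differently, and these four compounds cannot settle which, so the step seen on one core cannot be relied on to carry over in full to another.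

Only trifluoromethyl has been shown in place of this hydrogen, so it remains open whether a nitrile or a chlorine atom on the same carbon would give a similar step on either core. Repeat measurements of these four compounds would also show more clearly whether the two steps really differ.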